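A second methoxy on a short-lived compound

The source may report more compounds than this note shows. Statements on the series, on what has been measured and on what is new or still open speak of the compounds shown alone.

In an ADME assay on microsomes from liver (Rattus norvegicus) for metabolic stability, read by LC-MS, using NADPH, at 37 degrees C (a lower number here means that the compound disappears faster, a higher number that the compound lasts longer), compound 1 `Cc1oc(-c2c(Cl)cccc2Br)nc1CN1CCC(C(=O)NCCCN2C[C@H](C)C[C@H](C)C2)CC1` gives 0.0233 h, and compound 2 `COc1cccc(Cl)c1-c1nc(CN2CCC(C(=O)NCCCN3C[C@H](C)C[C@H](C)C3)CC2)c(C)o1` gives 0.055 h, the higher of the two numbers. Compound 3 `COc1cccc(OC)c1-c1nc(CN2CCC(C(=O)NCCCN3C[C@H](C)C[C@H](C)C3)CC2)c(C)o1` puts methoxy in place of chloro on an aromatic carbon, turning 2-chloro-6-methoxyphenyl into 2,6-dimethoxyphenyl: methoxy in place of chloro on an aromatic carbon. Among the measured compounds shown here, the one measured step that bears on this, a 2.4-fold higher number from compound 1 to compound 2 (0.37 log units; beyond the scatter), was modest and also brought in methoxy, there in place of bromo. A single step is thin evidence, so the expected change, a 1.6-fold higher number from compound 2 to compound 3 (0.21 log units; within the scatter), runs the same way but is estimated to be smaller. The estimated half-life of compound 3 is 0.09 h, with a range from 0.04 h to 0.2 h.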

Compound 3, half-life: 0.2 h
Compound 3: middle estimate off by 2.2-fold (0.35 log units), on the low side; measured number inside the range.
By their numbers in this assay, from the lowest: compound 1; then compound 2; then compound 3.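

In this assay, methoxy in place of chloro also raises the number (a 3.6-fold higher number from compound 2 to compound 3 (0.56 log units; beyond the scatter)), so the rise is no longer tied to the loss of bromo alone. With both halogens replaced, the 2,6-dimethoxyphenyl compound stands well clear of the bromo-chloro starting point (an 8.6-fold higher number from compound 1 to compound 3 (0.93 log units; beyond the scatter)), and compound 3 lasts longest of the three, beyond the scatter from each of the others. Nothing measured here explains why the half-life lengthens. As far as these compounds go, how an ethoxy group, a fluoro group or an amine at this place would compare remains open.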